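This account rests on a few compounds, and the source may have more. Where it says the series, first, only, none or still open, it means among the compounds named here.

Working notes on a small set of compounds sharing one core, all run in an assay on CHO cells for displacement of a labelled ligand from adenosine receptor A3 (Homo sapiens), read by scintillation counting, with a stated time of 120 min, tested at 1 uM; a lower number here means less inhibition, a higher number more inhibition at the concentration tested (going by the name of the read-out). Compound 1, `Cc1nc2sc(-c3cccnc3)nc2c(=O)[nH]1`, gives 33%. Compound 2, `Cc1nc2sc(Nc3ccc(Cl)cc3)nc2c(=O)[nH]1`, gives 49%. Compound 3, `CCOc1nc(C)nc2sc(-c3ccccc3)nc12`, gives 6%, the lowest of the three numbers; compound 1 stands higher by a margin beyond the usual scatter, and compound 2 stands higher still, also beyond it. Within the data shown here, no two of the measured compounds differ at a single place, so no measured step is available as a guide for what a single change does here.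

Compound 4, `CCOc1nc(C)nc2sc(-c3ccc(C)cc3)nc12`, is the next compound to go into this assay. It differs from compound 3 in one place: methyl in place of hydrogen on an aromatic carbon. Among the measured compounds shown here, nothing among the measured compounds shows what this change does, so the expectation rests on the small size of the change alone. The expected step is a number 4 percentage points higher from compound 3 to compound 4 (within the scatter), most likely within the scatter and with no direction claimed. Compound 4 is therefore estimated to give about 10%, in a range from 0% to 30%.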

Compound 4, a percentage reported as inhibition, at one concentration (the size of the read-out at that concentration, not a potency): 5%
Compound 4: the middle estimate sits 5 percentage points above what was measured; the range from low to high includes it.
By their numbers in this assay, from the lowest: compounds 4 and 3 (each within the scatter of the next); then compound 1; then compound 2.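

In this assay, methyl in place of hydrogen on an aromatic carbon, para to a large group, comes with a number 1 percentage points lower from compound 3 to compound 4 (within the scatter), the first single change measured in this series. At this position, then, one added methyl leaves the two numbers within the scatter of each other, and compound 3 and compound 4 cannot be told apart in this read-out. Nothing measured on these compounds offers an explanation for this result.

From the compounds shown here alone, whether another group at the same place, such as an amine, a carboxylic acid or a longer chain, would shift the number beyond the scatter remains open. Also open is what separates compound 3 and compound 4 from compound 1 and compound 2, as no single change among the compounds shown connects the two pairs.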